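Compound 3 trades pyrrolidin-1-yl for isopropyl

The source may hold more compounds than are shown below. What is called first, only, known or untested is meant among the compounds shown, and "the series" means these compounds.

In an ADME assay on HepG2 cells (Homo sapiens) for cytotoxicity (a lower number here means that less compound is tolerated, a higher number that more compound is tolerated), compound 1 (`CCOC(=O)CN(C)CC#Cc1cc2ncnc(Nc3ccc(OCc4cccc(F)c4)c(Cl)c3)c2s1`) gives 26 uM and compound 2 (`CC(C)(C)CC#Cc1cc2ncnc(Nc3ccc(OCc4cccc(F)c4)c(Cl)c3)c2s1`) gives 29.3 uM while compound 3 (`Fc1cccc(COc2ccc(Nc3ncnc4cc(C#CCN5CCCC5)sc34)cc2Cl)c1`) stands lowest of the three at 4.9 uM on this scale. Compound 4 (`CC(C)CC#Cc1cc2ncnc(Nc3ccc(OCc4cccc(F)c4)c(Cl)c3)c2s1`) has isopropyl in place of pyrrolidin-1-yl on a saturated chain carbon bound to a triple-bonded carbon. The nearest measured step is the one that put pyrrolidin-1-yl in place of tert-butyl (a 6.0-fold lower number from compound 2 to compound 3 (0.78 log units; beyond the scatter)), and pyrrolidin-1-yl in place of ((ethoxycarbonyl)methyl)(methyl)amino gave a step of like size (a 5.3-fold lower number from compound 1 to compound 3 (0.72 log units; beyond the scatter)). The two groups that pyrrolidin-1-yl replaced do not separate (a 1.1-fold higher number from compound 1 to compound 2 (0.05 log units; within the scatter)). Going by the values given here, no measured compound carries isopropyl itself. Isopropyl, like tert-butyl, holds carbon only, so compound 4 is expected to sit closer to compound 2 (29.3 uM) than to compound 3 (4.9 uM). A modest rise is therefore expected (a 4.9-fold higher number from compound 3 to compound 4 (0.69 log units; beyond the scatter)). For compound 4 the estimate is 24 uM within an expected range (11 uM to 45 uM).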

Compound 4, half-maximal toxic concentration: > 32 uM
Compound 4: only a limit was reported; the forecaster's own chance of this, stated with the estimate: 5%; middle value at least 1.3-fold (0.12 log units) from the limit.
By their numbers in this assay, from the lowest: compound 3; then compounds 1 and 2 (each within the scatter of the next). At a limit, above all of these: compound 4.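

In this assay compound 4 is reported only as a limit, > 32 uM. Even so, isopropyl in place of pyrrolidin-1-yl on a saturated chain carbon bound to a triple-bonded carbon gives an at least 6.5-fold higher number from compound 3 to compound 4 (0.81 log units; beyond the scatter). A second all-carbon group thus stands clear of compound 3, as does compound 1, which also carries a nitrogen at this place, and the low number remains with pyrrolidin-1-yl alone among the four. The other two steps to the limit give only an at least 1.0-fold higher number from compound 2 to compound 4 (0.03 log units; that floor lies within the scatter) and an at least 1.2-fold higher number from compound 1 to compound 4 (0.09 log units; that floor lies within the scatter), and they cannot be read, because their floors lie within the scatter at the limit: the limit of > 32 uM in this assay, at which 1 of the 4 values shown sits.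

Going by these compounds, how far compound 4 lies past its limit stays open. So does whether the low number follows the ring of pyrrolidin-1-yl, which a cyclopentyl, a piperidin-1-yl or an open dimethylamino group at this place would help to tell.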